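From 4-acetylphenyl to 3-methoxyphenyl on an aromatic nitrogen

The compounds below may be only part of what the source reports. "The series", "measured", "known", "first", "only" and "open" are said of these compounds alone.

Measured in a functional assay on MCF7 cells (Homo sapiens) for cytotoxicity, read by MTT assay, with a stated time of 48 h; on this read-out higher numbers stand for weaker inhibition and lower numbers for stronger inhibition:
- compound 1 `C=C1CCC[C@]2(C)CCC(c3cn(-c4ccc(C(C)=O)cc4)nn3)=CC[C@@]12C`: 65400 nM
- compound 2 `C=C1CCC[C@]2(C)CCC(c3cn(CC(=O)Nc4ccc(C)cc4)nn3)=CC[C@@]12C`: 80100 nM

The two values lie within the scatter of each other, so compound 1 does not stand apart from compound 2 on these numbers. Compound 3 `C=C1CCC[C@]2(C)CCC(c3cn(-c4cccc(OC)c4)nn3)=CC[C@@]12C` has not yet been measured. It carries 3-methoxyphenyl in place of 4-acetylphenyl on an aromatic nitrogen of a five-membered aromatic ring with 3 nitrogen (3-methoxyphenyl in place of 4-acetylphenyl on an aromatic nitrogen). Among the measured compounds shown here, no step between measured compounds shows the effect of such an exchange in this assay. Compound 2 gives 80100 nM and compound 1 gives 65400 nM, so no large step is expected. The estimated change, a 1.1-fold lower number from compound 1 to compound 3 (0.02 log units; within the scatter), is expected to stay within the scatter, in neither direction. For compound 3 the expected value is 62000 nM, with an estimated range from 28000 nM to 130000 nM.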

Compound 3, half-maximal inhibitory concentration: 56200 nM
Beside the measured number, compound 3's estimate is 1.1-fold (0.04 log units) above it; measured number inside the range.
By their numbers in this assay, from the lowest: compounds 3, 1 and 2 (each within the scatter of the next).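

In this assay, among the compounds shown here, putting 3-methoxyphenyl in place of 4-acetylphenyl on the aromatic nitrogen gives a 1.2-fold lower number from compound 1 to compound 3 (0.07 log units; within the scatter), the first step that can be read at this position, and it lies within the scatter. This exchange, which removes the double bond outside aromatic rings and leaves the count of hydrogen-bond acceptors as it was, therefore does not separate the two groups on this read-out. No measured property bears on this result, so the data offer no explanation for it.

The exchange alters both the substituent and its place on the phenyl ring, so the compounds shown cannot separate these two changes. Going by these compounds, it remains open whether plain phenyl, or a phenyl ring carrying an amine or a carboxylic acid, would move the number beyond the scatter.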